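The compounds below may be only part of what the source reports. "The series", "measured", "known", "first", "only" and "open" are said of these compounds alone.

Measured in a functional assay on brain (Rattus norvegicus, strain Wistar) for inhibition; on this read-out lower numbers stand for stronger inhibition and higher numbers for weaker inhibition:
compound 1 `CCCCOc1ccc(-c2c(C)[nH]c(=O)n2C2CCCCC2)cc1`: 13900 nM
compound 2 `Cc1[nH]c(=O)n(C2CCCCC2)c1-c1ccc(OC(C)C)cc1`: 13000 nM
compound 3 `CCCCCCOc1ccc(-c2c(C)[nH]c(=O)n2C2CCCCC2)cc1`: 8500 nM

Compound 3 cannot be separated from the other two, with a 1.6-fold lower number from compound 1 to compound 3 (0.21 log units; within the scatter) and a 1.5-fold lower number from compound 2 to compound 3 (0.18 log units; within the scatter).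

Next is compound 4 `CCCCCCCCCCOc1ccc(-c2c(C)[nH]c(=O)n2C2CCCCC2)cc1`, which differs from compound 3 in the chain on the oxygen: butyl in place of hydrogen on a saturated chain carbon, six bonds along the chain from an oxygen on an aromatic ring.

Within the data shown here, the closest precedent is the same kind of change made earlier in the chain, the ethyl added in a 1.6-fold lower number from compound 1 to compound 3 (0.21 log units; within the scatter). The swap of isopropyl for hexyl, a 1.5-fold lower number from compound 2 to compound 3 (0.18 log units; within the scatter), and that of butyl for isopropyl, a 1.1-fold lower number from compound 1 to compound 2 (0.03 log units; within the scatter), bear on it as well. All three steps are small, and none leaves the scatter. The new chain is longer than any measured so far, so the data do not cover this length directly. No step beyond the scatter is therefore expected in this assay. The expected change is a 1.2-fold lower number from compound 3 to compound 4 (0.08 log units; within the scatter). For compound 4 the estimated value is 7000 nM, with an expected range of 2500 nM to 20000 nM.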

Compound 4, half-maximal inhibitory concentration: 10500 nM
Beside the measured number, compound 4's estimate is 1.5-fold (0.18 log units) below it; measured number inside the range.
By their numbers in this assay, from the lowest: compounds 3, 4, 2 and 1 (each within the scatter of the next).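

In this assay the decyl chain of compound 4 does not separate from the shorter chains: the butyl added to the hexyl chain gives a 1.2-fold higher number from compound 3 to compound 4 (0.09 log units; within the scatter), the decyl in place of isopropyl gives a 1.2-fold lower number from compound 2 to compound 4 (0.09 log units; within the scatter), and the hexyl added to the butyl chain gives a 1.3-fold lower number from compound 1 to compound 4 (0.12 log units; within the scatter). Across butyl, isopropyl, hexyl and decyl on the oxygen, the four compounds therefore stay within the scatter of one another, and this position accepts the longest chain so far without a readable change. No measured information bearing on this flat result is available.

The compounds shown carry only plain alkyl chains on the oxygen, so whether a chain ending in an amine or a carboxylic acid would give a step beyond the scatter stays open. Going by these compounds, whether a change elsewhere on the shared core would do so also stays open.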